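Saturating the Vinyl Group on the Indole Core

The source may hold more compounds than are shown below. What is called first, only, known or untested is meant among the compounds shown, and "the series" means these compounds.

Going by the values given here, compound 2 `C=Cc1ccc2ccn(CCN3CCCN(C)CC3)c2c1` stands highest of the two compounds measured so far in an assay on HEK293 cells for binding affinity to 5-hydroxytryptamine receptor 7 (Homo sapiens), read by radioligand binding, tested at 1 uM (on this read-out lower numbers stand for less inhibition and higher numbers for more inhibition at the one concentration tested (going by the name of the read-out)), where compound 2 gives 79%. Its neighbour, compound 1 `CN1CCCN(CCn2ccc3ccc(F)cc32)CC1`, gives 60%, a step of a number 19 percentage points higher from compound 1 to compound 2 (beyond the scatter). Compound 3 `CCc1ccc2ccn(CCN3CCCN(C)CC3)c2c1` differs from compound 2 by ethyl in place of vinyl on an aromatic carbon. Among the compounds with values here, the single measured step bears only loosely on this change, since it swapped fluoro for vinyl rather than saturating the vinyl; no measured pair tests the double bond itself. Compound 3 is therefore expected to land close to compound 2, a step of a number 6 percentage points lower from compound 2 to compound 3 (within the scatter), within the scatter. Compound 3 is estimated at 73%, between 56% and 88%.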

Compound 3, a percentage reported as inhibition, at one concentration (the size of the read-out at that concentration, not a potency): 66%
The estimate for compound 3 lay 7 percentage points above the measured number, and the stated range covers the measured number.
By their numbers in this assay, from the lowest: compounds 1 and 3 (each within the scatter of the next); then compound 2.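

In this assay the vinyl group does not act merely as two carbons at this place, since a number 13 percentage points lower from compound 2 to compound 3 (beyond the scatter) comes with the loss of the double bond alone, the heavy-atom count staying the same. Ethyl, by contrast, does not separate from fluoro here, with a number 6 percentage points higher from compound 1 to compound 3 (within the scatter) being no more than the scatter allows. Nothing measured explains why the double bond matters.

Going by these compounds, whether an ethynyl group, with its triple bond, would match or pass compound 2 remains open. So does whether a longer chain such as propyl or a methoxy group would behave like ethyl.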